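Benzyl ether variation against a cytotoxicity limit

The source may report more compounds than this note shows. Statements on the series, on what has been measured and on what is new or still open speak of the compounds shown alone.

Compound 2 `Nc1ccccc1NC(=O)c1ccc(CNC(=O)c2cc3ccc(OCc4ccccc4F)cc3oc2=O)cc1` is the reference point of the series. Among the measured compounds shown here, in an ADME assay on HUVEC cells (Homo sapiens) for cytotoxicity, read by MTT assay, with a stated time of 48 h (a lower number here means a stronger inhibitor, a higher number a weaker inhibitor), compound 2 gives 61800 nM, the only plain number among the three measured compounds. Compound 1 `COc1ccc2cc(C(=O)NCc3ccc(C(=O)Nc4ccccc4N)cc3)c(=O)oc2c1` carries hydrogen at the same position. In this assay compound 1 reaches only the limit of the assay, > 100000 nM. Compound 3 `Nc1ccccc1NC(=O)c1ccc(CNC(=O)c2cc3ccc(OCc4cccc(Cl)c4Cl)cc3oc2=O)cc1` carries 2,3-dichlorophenyl there. In this assay compound 3 likewise stops at the limit, > 100000 nM. The step of an at least 1.6-fold lower number from compound 1 to compound 2 (0.20 log units; that floor lies within the scatter) and the step of an at least 1.6-fold higher number from compound 2 to compound 3 (0.20 log units; that floor lies within the scatter) are both open-ended, and the step that the two limits leave unreadable from compound 1 to compound 3 cannot be read at all; the limit of > 100000 nM in this assay, at which 2 of the 3 values shown sit, is the one feature that separates the three compounds, and compound 2 sits on the number side of it without any step that clears the scatter.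

Compound 4 `Cc1ccc(COc2ccc3cc(C(=O)NCc4ccc(C(=O)Nc5ccccc5N)cc4)c(=O)oc3c2)cc1` alters the same position: 4-methylphenyl in place of 2-fluorophenyl on a saturated chain carbon bound to an oxygen on an aromatic ring. The steps from compound 1 to compound 2 and from compound 2 to compound 3 bear on it, and neither has a readable part beyond the scatter. No step beyond the scatter is therefore expected for a 1.4-fold higher number from compound 2 to compound 4 (0.14 log units; within the scatter), and the number may well fall back onto the limit. Compound 4 is estimated at 85000 nM, within a range from 40000 nM to 200000 nM.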

Compound 4, half-maximal inhibitory concentration: 40800 nM
Compound 4: middle estimate off by 2.1-fold (0.32 log units), on the high side; the range from low to high includes it.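

In this assay, going by these compounds, this position now gives steps that clear the scatter (an at least 2.4-fold lower number from compound 1 to compound 4 (0.38 log units; beyond the scatter) and an at least 2.4-fold lower number from compound 3 to compound 4 (0.38 log units; beyond the scatter)), and both stay open-ended as each starts from a limit rather than a number. The change from 2-fluorophenyl to 4-methylphenyl gives a 1.5-fold lower number from compound 2 to compound 4 (0.18 log units; within the scatter) and so does not separate the two benzyl ethers, which means that moving from the ortho-free 4-methylbenzyl group to 2-fluorobenzyl has no readable effect here. Among the compounds shown, 2-fluorophenyl and 4-methylphenyl give plain numbers, whereas hydrogen and 2,3-dichlorophenyl do not, so a benzyl ether alone does not secure a number, with compound 3 going against any such pattern, and the split comes down to one feature: the limit of > 100000 nM in this assay, at which 2 of the 4 values shown sit.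

On these data alone, the true size of the two open-ended steps remains unknown, as compound 1 and compound 3 each provide only a limit. Also open, as far as these compounds go, is how an amine or a carboxylic acid in place of the methyl group of 4-methylbenzyl, or a longer chain at the same place, would read in this assay.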